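Swapping Methoxypiperidine for Dimethylmorpholine on the Urea Carbonyl

This account rests on a few compounds, and the source may have more. Where it says the series, first, only, none or still open, it means among the compounds named here.

Compound 2 `COC1CCCN(C(=O)N2CC(c3nc(-c4cccc(Cl)c4)no3)C2)C1` reaches only a limit in an assay on HEK293 cells for positive allosteric modulation of metabotropic glutamate receptor 5 (Homo sapiens), read by FLIPR (a higher number here means that more compound is needed for the effect, a lower number that less compound is needed), > 10000 nM. Compound 1 `CC1CCN(C(=O)N2CC(c3nc(-c4cccc(Cl)c4)no3)C2)CC1` gives 865 nM in this assay. Among the measured compounds shown here, the single measured step, an at least 11-fold higher number from compound 1 to compound 2 (1.06 log units; beyond the scatter), ends at the limit noted in the limit of > 10000 nM in this assay, at which 1 of the 2 values shown sits. Compound 3 `CC1CN(C(=O)N2CC(c3nc(-c4cccc(Cl)c4)no3)C2)CC(C)O1` differs from compound 2 by 2,6-dimethylmorpholin-4-yl in place of 3-methoxypiperidin-1-yl on a carbonyl carbon. For the measured compounds named here, the only step that bears on this change starts from a limit, so its true size is unknown and the direction from compound 2 is uncertain; a partial return toward compound 1 is expected rather than none. Compound 3 is therefore expected to give 4000 nM, within a range from 1000 nM to 15000 nM. That would amount to an expected step of an at least 2.5-fold lower number from compound 2 to compound 3 (0.39 log units; beyond the scatter).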

Compound 3, half-maximal effective concentration: > 10000 nM
Compound 3: no number, only a limit (the forecaster's own chance of this, stated with the estimate: 40%); middle value at least 2.5-fold (0.39 log units) from the limit.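

In this assay compound 3 also stops at a limit, > 10000 nM, so 2,6-dimethylmorpholin-4-yl on the carbonyl carbon joins 3-methoxypiperidin-1-yl at that limit. Put in place of 4-methylpiperidin-1-yl, it gives an at least 11-fold higher number from compound 1 to compound 3 (1.06 log units; beyond the scatter). The step between the two limit compounds cannot be read, and only compound 1 has a number, with the others at one shared limit: the limit of > 10000 nM in this assay, at which 2 of the 3 values shown sit.

Still open, from the compounds shown here alone, is how far beyond that limit compound 2 and compound 3 lie. Also open, going by these compounds, is whether a plain morpholine, an unsubstituted piperidine or a 4-methoxypiperidine on the same carbonyl carbon would give a number.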